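A ring-free end group replaces an aromatic one

This account rests on a few compounds, and the source may have more. Where it says the series, first, only, none or still open, it means among the compounds named here.

Compound 1 `COc1ccc(C(=NNC(=O)NNC(=O)NCCCC(C)Nc2cc(OC)cc3cccnc23)c2ccc(OC)cc2)cc1` gives 1000 nM
Compound 2 `COc1cc(NC(C)CCCNC(=O)NNC(=O)Nc2ccc(Cl)c(C(F)(F)F)c2)c2ncccc2c1` gives 2000 nM

For the measured compounds named here, both compounds were measured in a functional assay on MCF7 cells (Homo sapiens) for inhibition, read by MTT assay, with a stated time of 4 days (a lower number here means a stronger inhibitor, a higher number a weaker inhibitor), and their values lie within the usual scatter of each other, so compound 2 stands level with the only other measured compound.

Compound 3 `COc1cc(NC(C)CCCNC(=O)NNC(=O)N(CCO)CCO)c2ncccc2c1` keeps the shared core and chain of compound 2 and changes one group, as follows: bis(2-hydroxyethyl)amino in place of (4-chloro-3-(trifluoromethyl)phenyl)amino on a carbonyl carbon. Bis(2-hydroxyethyl)amino takes the place of (4-chloro-3-(trifluoromethyl)phenyl)amino on a carbonyl carbon, so the six-membered aromatic ring of carbon only is lost.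

Going by the values given here, no measured compound shows a ring-free group at this place, and no measured step shows what such a swap does. The expectation therefore has thin support. It starts from compound 2 at 2000 nM and points to weaker inhibition in this assay rather than to no change. The expected size of the move is a 10-fold higher number from compound 2 to compound 3 (1.00 log units; beyond the scatter) and it runs toward a higher number. As far as these compounds go, for compound 3 the estimated value is 20000 nM with an expected range from 5000 nM to 80000 nM and the outcome remains open.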

Compound 3, half-maximal inhibitory concentration: 29000 nM
Beside the measured number, compound 3's estimate is 1.5-fold (0.16 log units) below it, and the stated range covers the measured number.
By their numbers in this assay, from the lowest: compounds 1 and 2 (each within the scatter of the next); then compound 3.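

In this assay, for the compounds shown here, putting bis(2-hydroxyethyl)amino in place of (4-chloro-3-(trifluoromethyl)phenyl)amino on a carbonyl carbon gives a 15-fold higher number from compound 2 to compound 3 (1.16 log units; beyond the scatter), and this is the first single-place comparison available, since compounds 1 and 2 are not joined by such a step. It shows that the group at this place matters for the read-out: within this pair, the end group with the six-membered aromatic ring of carbon only goes with clearly stronger inhibition than the ring-free end group. No measurement shown here accounts for the size or direction of this step.

This single swap removes the ring, the chlorine and the trifluoromethyl group and adds two hydroxyl groups all at once, so the compounds shown leave open which of these changes carries the loss. A plain phenylamino group would separate the ring from its chlorine and trifluoromethyl substituents, while a diethylamino group would show whether a ring-free end group without hydroxyl groups behaves like bis(2-hydroxyethyl)amino at this place.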